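Swapping a methoxy for a nitro group on compound 2

The source may report more compounds than this note shows. Statements on the series, on what has been measured and on what is new or still open speak of the compounds shown alone.

Compound 1 `Cc1ccc(-c2csc(N3C(=O)c4ccc(F)cc4C3=O)n2)cc1`: 44400 nM
Compound 2 `COc1ccc(-c2csc(N3C(=O)c4ccc(F)cc4C3=O)n2)cc1`: 41300 nM

In a functional assay on PC-3 cells (Homo sapiens) for antiproliferative activity, read by MTT assay, with a stated time of 48 h (a lower number here means a stronger inhibitor, a higher number a weaker inhibitor), compound 1 gives 44400 nM and compound 2 gives 41300 nM. The two numbers lie within the scatter of each other, so compound 2 stands together with compound 1 rather than apart from it. For the measured compounds named here, the only measured step, a 1.1-fold lower number from compound 1 to compound 2 (0.03 log units; within the scatter), changes the group on the aromatic carbon and leaves the number essentially where it was.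

Compound 3 `O=C1c2ccc(F)cc2C(=O)N1c1nc(-c2ccc([N+](=O)[O-])cc2)cs1` differs from compound 2 by nitro in place of methoxy on an aromatic carbon. Going by the values given here, no measured step covers a nitro group; the one step that touches the same place shows that exchanging one small group for another there did not move the number beyond the scatter. On that basis compound 3 is expected to show no step beyond the scatter, as a 1.0-fold lower number from compound 2 to compound 3 (0.01 log units; within the scatter). Compound 3 is therefore estimated at 40000 nM, with a range from 15000 nM to 100000 nM.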

Compound 3, half-maximal inhibitory concentration: 39900 nM
Compound 3: middle estimate off by 1.0-fold (0.00 log units), on the high side, within the range that was stated.
By their numbers in this assay, from the lowest: compounds 3, 2 and 1 (each within the scatter of the next).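

In this assay the same aromatic carbon has now carried methyl, methoxy and nitro, and the new steps, a 1.0-fold lower number from compound 2 to compound 3 (0.01 log units; within the scatter) and a 1.1-fold lower number from compound 1 to compound 3 (0.05 log units; within the scatter) both stay within the scatter. For the compounds shown here, compounds 1 and 2 showed this for only one exchange, whereas nitro brings more heavy atoms and hydrogen-bond acceptors than methoxy, plus a double bond outside aromatic rings, and the numbers of all three compounds still stand together. Nothing available explains why the number holds steady across these three groups.

The compounds shown leave open whether an amine, a carboxylic acid or a longer chain on this carbon would also stay within the scatter of these numbers. They also leave open whether changes elsewhere on the shared core would move the number in this assay at all.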